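The source may report more compounds than this note shows. Statements on the series, on what has been measured and on what is new or still open speak of the compounds shown alone.

Compound 2, with the structure `COc1ccc(-c2[nH]c3ccc(OC)cc3c2/C=C(\C#N)S(=O)(=O)c2ccccc2)cc1`, is examined in a functional assay on MOLT-4 cells (Homo sapiens) for inhibition, read by sulforhodamine B assay, with a stated time of 48 h (on this read-out higher numbers stand for weaker inhibition of growth and lower numbers for stronger inhibition of growth), where compound 2 gives 765 nM. Among the three measured values, compound 2 stands second highest. Its closest neighbour is compound 1, built as `COc1ccc(-c2[nH]c3ccccc3c2/C=C(\C#N)S(=O)(=O)c2ccccc2)cc1`, and in this assay compound 1 gives 871 nM; the step from compound 1 to compound 2 is a 1.1-fold lower number from compound 1 to compound 2 (0.06 log units; within the scatter), and the change behind it is a methoxy in place of hydrogen on an aromatic carbon. The remaining compound is compound 3, with the structure `COc1ccc(-c2[nH]c3ccc(OC)cc3c2C=C(C#N)C#N)cc1`, and in this assay compound 3 gives 369 nM, a lower number than that of compound 2.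

The next compound is compound 4, drawn as `COc1ccc2[nH]c(-c3ccccc3)c(/C=C(\C#N)S(=O)(=O)c3ccccc3)c2c1`. It differs from compound 2 by hydrogen in place of methoxy on an aromatic carbon. Going by the values given here, the only measured step that concerns a methoxy against hydrogen on an aromatic carbon is the one from compound 1 to compound 2, and that step stayed within the scatter, though it sits at a different place. On that basis no step beyond the scatter is expected; the change from compound 2 to compound 4 is estimated at a 1.0-fold higher number from compound 2 to compound 4 (0.02 log units; within the scatter). Compound 4 is therefore expected to give about 800 nM, within a range from 350 nM to 1900 nM.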

Compound 4, concentration for 50% growth inhibition: 4700 nM
The estimate for compound 4 lay 5.9-fold (0.77 log units) below the measured number; measured number above the stated range.
By their numbers in this assay, from the lowest: compound 3; then compounds 2 and 1 (each within the scatter of the next); then compound 4.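

Going from the 4-methoxyphenyl group to phenyl gives a 6.1-fold higher number from compound 2 to compound 4 (0.79 log units; beyond the scatter) in this assay, so this methoxy counts for much in growth inhibition. The earlier swap of methoxy and hydrogen, made at a different place, gave only a 1.1-fold lower number from compound 1 to compound 2 (0.06 log units; within the scatter), which shows that the same small change cannot be carried over from one place on these molecules to another. Nothing measured here on the compounds explains why the methoxy matters so much at this place.

The compounds shown leave open whether only a methoxy serves at this place, or whether a hydroxyl, an ethoxy or an amine would hold the number as well. They also leave open whether the phenyl swap would cost as much in compound 3 , which carries two nitrile groups instead of the nitrile and phenylsulfonyl pair.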